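Swapping the Aryl Group Toward a Tolyl Analogue

This account rests on a few compounds, and the source may have more. Where it says the series, first, only, none or still open, it means among the compounds named here.

Compound 1 `Oc1c(C(Nc2ccccn2)c2ccccc2F)ccc2cccnc12`: > 10000 nM
Compound 2 `Oc1c(C(Nc2ccccn2)c2c(Cl)cccc2Cl)ccc2cccnc12`: 6900 nM

In a functional assay on U-87MG ATCC cells for inhibition, with U-87 MG (Homo sapiens) as the target, read by MTT assay, with a stated time of 72 h (on this read-out higher numbers stand for weaker inhibition and lower numbers for stronger inhibition), compound 1 gives > 10000 nM, which is a limit of the assay and not a number. Compound 2 gives 6900 nM in this assay and so holds the only number shown. Within the data shown here, the one measured step, an at least 1.4-fold lower number from compound 1 to compound 2 (0.16 log units; that floor lies within the scatter), has a floor that lies within the scatter because the limit of > 10000 nM in this assay, at which 1 of the 2 values shown sits, sets it. Compound 3 `Cc1ccc(C(Nc2ccccn2)c2ccc3cccnc3c2O)cc1` differs from compound 2 by 4-methylphenyl in place of 2,6-dichlorophenyl on a saturated chain carbon bound to an aromatic carbon and a nitrogen on an aromatic ring. Among the measured compounds shown here, only that single step bears on this change, and it shows no step beyond the scatter, so in this assay nothing beyond the scatter is expected in either direction. Compound 3 is therefore estimated at 8000 nM, with a range from 2500 nM to 30000 nM, which means an expected step of a 1.2-fold higher number from compound 2 to compound 3 (0.06 log units; within the scatter).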

Compound 3, half-maximal inhibitory concentration: > 10000 nM
Compound 3 was reported as a limit (the forecaster's own chance of this, stated with the estimate: 40%); at least 1.2-fold (0.09 log units) between middle value and limit.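

With 4-methylphenyl in place of 2,6-dichlorophenyl, a ring without halogen has now been tried at this position, and this assay records an at least 1.4-fold higher number from compound 2 to compound 3 (0.16 log units; that floor lies within the scatter). Compound 3 gives > 10000 nM, which is a limit of the assay and not a number, so compound 2 remains the only one of the three with a measured value. The step between compound 1 and compound 3 cannot be read, and the real size of these changes stays hidden because so many results stop at the same ceiling: the limit of > 10000 nM in this assay, at which 2 of the 3 values shown sit.

Going by these compounds, it remains open whether a phenyl ring carrying an amine or a carboxylic acid at this place would give a clearly lower number. Also open, on these data alone, is whether a single chlorine on the ring would give a measurable value, as the two chlorines of compound 2 do.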